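This account rests on a few compounds, and the source may have more. Where it says the series, first, only, none or still open, it means among the compounds named here.

Measured so far in an assay on HeLa cells for inhibition of sphingosine-1-phosphate transporter SPNS2 (Mus musculus), read by LC-MS, tested at 2 uM; on this read-out lower numbers stand for less inhibition and higher numbers for more inhibition at the one concentration tested (going by the name of the read-out): compound 1 `CCCCCCCCCCc1ccc(-c2noc(CC3CNC3)n2)cc1` gives 63%; compound 2 `CCCCCCCCCCc1ccc(-c2noc([C@@H]3CCCN3)n2)cc1` gives 21%; compound 3 `CCCCCCCCCCc1ccc(-c2noc(CC(CN)OC(C)=O)n2)cc1` gives 0%.

Compound 3 stands lowest of the three numbers, with compound 2 nearest and compound 1 furthest. Compound 4 `CCCCCCCCCCc1ccc(-c2noc(CCCN3CCCCC3)n2)cc1` differs from compound 3 in one place: a group of 8 heavy atoms (7 carbon, 1 nitrogen; one six-membered non-aromatic ring with 1 hetero atom) in place of a group of 7 heavy atoms (4 carbon, 1 nitrogen, 2 oxygen; no ring), on a saturated chain carbon bound to an aromatic carbon. Going by the values given here, the steps that bear on this change are those into compound 3 from the ring-bearing, nitrogen-carrying groups, a number 63 percentage points lower from compound 1 to compound 3 (beyond the scatter) and a number 21 percentage points lower from compound 2 to compound 3 (beyond the scatter), both downward beyond the scatter. Reversing toward a nitrogen-containing ring therefore points upward in this assay, though the new group keeps no hydrogen-bond donor and differs from both earlier rings. For compound 4 a step of a number 30 percentage points higher from compound 3 to compound 4 (beyond the scatter) is expected. Compound 4 is estimated at 30%, within 5% to 60%.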

Compound 4, a percentage reported as inhibition, at one concentration (the size of the read-out at that concentration, not a potency): 0%
For compound 4 the middle estimate is 30 percentage points above the measured one, and the stated range ends above it.
By their numbers in this assay, from the lowest: compounds 3 and 4 (each within the scatter of the next); then compound 2; then compound 1.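

In this assay, a six-membered nitrogen ring at this place does not by itself restore inhibition: 2-(piperidin-1-yl)ethyl in place of the ring-free group gives no change at the digits printed from compound 3 to compound 4 (within the scatter). The same group also gives a number 21 percentage points lower from compound 2 to compound 4 (beyond the scatter) and a number 63 percentage points lower from compound 1 to compound 4 (beyond the scatter), so having a ring with a nitrogen does not separate compound 4 from compound 3. No measurement here accounts for these steps.

As far as these compounds go, it remains open whether (1-methylazetidin-3-yl)methyl or piperidin-4-yl on the shared core would match compound 1, which would separate ring size from substitution on the ring nitrogen.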